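An Ester in Place of an Acid: Estimating Compound 4

The compounds below may be only part of what the source reports. "The series", "measured", "known", "first", "only" and "open" are said of these compounds alone.

Compound 1, `O=C(O)CCc1ccncc1-c1ccc2ccccc2c1`: > 10000 nM
Compound 2, `O=C(CCc1ccncc1-c1ccc2ccccc2c1)N1CCOCC1`: > 10000 nM
Compound 3, `CNC(=O)/C=C/c1ccncc1-c1ccc2cc[nH]c2c1`: 7680 nM

All three were tested in a functional assay on MDA-MB-231 cells (Homo sapiens) for inhibition, read by sulforhodamine B assay, with a stated time of 72 h; on this read-out higher numbers stand for weaker inhibition of growth and lower numbers for stronger inhibition of growth. For compound 1 the value is a limit of the assay and not a number, so it is known only to be a weak inhibitor of growth. For compound 2 the value is likewise a limit. Compound 3, whose carbonyl carries a methylamino group and whose side chain holds a double bond, gives 7680 nM, a measured number. For the measured compounds named here, the only step between measured neighbours, a step that the two limits leave unreadable from compound 1 to compound 2, cannot be sized: the limit of > 10000 nM in this assay, at which 2 of the 3 values shown sit.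

Compound 4, `CCOC(=O)/C=C/c1ccncc1-c1ccc2ccccc2c1`, differs from compound 1 in one place: 2-(ethoxycarbonyl)ethenyl in place of 2-carboxyethyl on an aromatic carbon. Going by the values given here, no measured step covers this change; the single step available swaps hydroxy for morpholin-4-yl and is unreadable. Compound 3 shows that a side chain with a double bond and a carbonyl without hydroxy can give a number inside the range of this assay. Compound 4 is therefore expected to move in the same direction, by a step of an at least 2.0-fold lower number from compound 1 to compound 4 (0.30 log units; that floor lies within the scatter). The estimated value of compound 4 is 5000 nM, with a range from 1500 nM to 15000 nM.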

Compound 4, concentration for 50% growth inhibition: 8090 nM
The estimate for compound 4 lay 1.6-fold (0.21 log units) below the measured number, and the stated range covers the measured number.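

In this assay, for the compounds shown here, putting 2-(ethoxycarbonyl)ethenyl in place of 2-carboxyethyl on this aromatic carbon, opposite the ring nitrogen and ortho to a large group, gives the first readable step at this position, with an at least 1.2-fold lower number from compound 1 to compound 4 (0.09 log units; that floor lies within the scatter) as its size. The change therefore takes the core of compound 1 from a limit of the assay to a real number, so this position can carry a group that gives a measurable result. That size is only a floor, not a full measurement of the change, because compound 1 gives a limit and not a number: the limit of > 10000 nM in this assay, at which 2 of the 4 values shown sit.

The change also alters several things at once: the chain gains a double bond, the acid becomes an ethyl ester, and the hydrogen-bond donor count falls, so this single step cannot show which of these matters. A 2-(ethoxycarbonyl)ethyl group, which keeps the ester on a chain without the double bond, and a 2-carboxyethenyl group, which keeps the double bond with a free carboxylic acid, would separate the two parts of the change.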